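Adding 2-hydroxyethoxy to compound 1: working notes

This account rests on a few compounds, and the source may have more. Where it says the series, first, only, none or still open, it means among the compounds named here.

Measured so far in a physicochemical assay for solubility, read by nephelometry, in phosphate buffer, at pH 7.4; a lower number here means a less soluble compound, a higher number a more soluble compound:
Compound 1 (`COc1cc(/C=C/C(=O)NCCn2c(C)cc3ccccc32)cc(OC)c1`) gives < 25000 nM as a limit
Compound 2 (`O=C(/C=C/c1ccc(OCCO)c(OCCO)c1)NCCn1c(C(F)(F)F)cc2ccccc21`) gives 67000 nM as a number

Compound 1 stands only at the limit < 25000 nM and has no number. Compound 3 (`COc1cc(/C=C/C(=O)NCCn2c(C)cc3ccccc32)cc(OC)c1OCCO`) carries 2-hydroxyethoxy in place of hydrogen on an aromatic carbon, ortho to two methoxy groups and para to a large group (2-hydroxyethoxy in place of hydrogen on an aromatic carbon). Among the measured compounds shown here, no measured step covers this change. The expectation of a rise in this assay rests on compound 2, which also carries 2-hydroxyethoxy and gives 67000 nM as its value. A modest upward move is expected, estimated as an at least 1.2-fold higher number from compound 1 to compound 3 (0.10 log units; that floor lies within the scatter) in size. For compound 3 the estimate is 32000 nM, with an expected range from 12000 nM to 80000 nM overall.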

Compound 3, solubility: 66000 nM
Compound 3: middle estimate off by 2.1-fold (0.31 log units), on the low side, within the range that was stated.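

On an aromatic carbon ortho to two methoxy groups and para to a large group, 2-hydroxyethoxy in place of hydrogen gives, in this assay, an at least 2.6-fold higher number from compound 1 to compound 3 (0.42 log units; beyond the scatter). The earlier compounds shown here offered no one-place reading of this change, since compound 2 differs from compound 1 in more than one place. The step is only a floor because compound 1 has a limit and not a number: the limit of < 25000 nM in this assay, at which 1 of the 3 values shown sits.

From the compounds shown here alone, whether a longer chain ending in hydroxyl, an amine or a carboxylic acid on this carbon would give a similar step remains open. Also open, going by these compounds, is how 2-hydroxyethoxy would behave on another aromatic carbon of compound 1.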